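Moving Two Fluorines on the Benzyl Ring

A few compounds are considered here, and "the series" means these few. Any claim that something is new, unique, unknown or untested is made for them only; others in the source may bear on it.

Among the measured compounds shown here, compound 1 `CCOC(=O)/C(O)=C/C(=O)c1cn(Cc2cc(F)cc(F)c2)c2cccc(OC)c12` gives 34700 nM in an ADME assay on MT4 cells (Homo sapiens) for cytotoxicity, read by MTT assay (a higher number here means that more compound is tolerated, a lower number that less compound is tolerated), one of only two numbers measured so far. The other comes from compound 2 `COc1cccc2c1c(C(=O)/C=C(\O)C(=O)O)cn2Cc1cc(F)cc(F)c1`, which gives 29500 nM in this assay; the step of a 1.2-fold lower number from compound 1 to compound 2 (0.07 log units; within the scatter) stays within the scatter. Compound 3 `CCOC(=O)/C(O)=C/C(=O)c1cn(Cc2cccc(F)c2F)c2cccc(OC)c12` differs from compound 1 by 2,3-difluorophenyl in place of 3,5-difluorophenyl on a saturated chain carbon bound to an aromatic nitrogen. For the measured compounds named here, no measured step touches this part of the molecule, so there is no basis here for a shift in either direction, and the expected step of a 1.0-fold lower number from compound 1 to compound 3 (0.01 log units; within the scatter) is none beyond the scatter. Compound 3 is therefore estimated at 34000 nM, within 15000 nM to 75000 nM.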

Compound 3, half-maximal cytotoxic concentration: 21100 nM
The estimate for compound 3 lay 1.6-fold (0.21 log units) above the measured number; low and high end bracket the measured number.
By their numbers in this assay, from the lowest: compounds 3, 2 and 1 (each within the scatter of the next).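

Among the compounds shown here, this is the first measured change to the benzyl part of the molecule: in this assay, 2,3-difluorophenyl in place of 3,5-difluorophenyl gives a 1.6-fold lower number from compound 1 to compound 3 (0.22 log units; within the scatter) on the same core. The same atoms, joined differently, therefore leave this cell read-out within its usual scatter. No measurement on hand offers an explanation for the size of this step.

Still open, on these data alone, is how a benzyl group carrying chlorine or methoxy would compare. Also open, as far as these compounds go, is whether the 2,3-difluorobenzyl group behaves alike when the ethyl ester is replaced by the free acid.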